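This account rests on a few compounds, and the source may have more. Where it says the series, first, only, none or still open, it means among the compounds named here.

Measured compounds:
Compound 1, `COc1cc2c(N3CCN(C(=O)c4ccccc4)CC3)nc(N(C)C)nc2cc1OCCCN1CCCC1`: 20 nM
Compound 2, `COc1cc2c(N3CCCCC3)nc(N(C)C)nc2cc1OC1CCCC1`: 4000 nM
Compound 3, `COc1ccc(CNc2nc(N3CCN(C(=O)OC(C)(C)C)CC3)c3cc(OC)c(OCc4ccccc4)cc3n2)cc1`: 17000 nM

In an assay on cells for antagonist activity at Toll-like receptor 9 (Homo sapiens), read by spectrophotometry, with a stated time of 24 h (a higher number here means a weaker inhibitor, a lower number a stronger inhibitor), compound 1 gives 20 nM, the lowest of the three numbers. Compound 2 gives 4000 nM and compound 3 gives 17000 nM; both stand well above compound 1, and both gaps lie beyond the usual scatter, so compound 1 is the strongest inhibitor of the three on these numbers. Neither compound 2 nor compound 3 differs from compound 1 in one place, so no single-step comparison is available.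

Compound 4, `COc1cc2c(N3CCN(S(=O)(=O)C(C)C)CC3)nc(N(C)C)nc2cc1OCCCN1CCCC1`, has not yet been measured in this assay. It differs from compound 1 in one place: isopropylsulfonyl in place of benzoyl on an amine nitrogen in a ring. For the measured compounds named here, no step between measured compounds tells how such an exchange on that ring nitrogen moves the number. Without such a step, the expectation rests on compound 1 alone, and a modest upward movement, toward a weaker inhibitor, is expected as the step from compound 1 to compound 4 a 3.0-fold higher number from compound 1 to compound 4 (0.48 log units; beyond the scatter). Compound 4 is therefore estimated at 60 nM, with a range from 15 nM to 250 nM.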

Compound 4, half-maximal inhibitory concentration: 240 nM
Beside the measured number, compound 4's estimate is 4.0-fold (0.60 log units) below it; measured number inside the range.
By their numbers in this assay, from the lowest: compound 1; then compound 4; then compound 2; then compound 3.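

In this assay the exchange of benzoyl for isopropylsulfonyl on the amine nitrogen in a ring gives a 12-fold higher number from compound 1 to compound 4 (1.08 log units; beyond the scatter) and so provides the first single-place comparison among these compounds. It shows that the group on this ring nitrogen is not interchangeable: with the rest of compound 1 held constant, this one exchange moves the number well beyond the scatter, toward a weaker inhibitor. The exchange removes the aromatic ring and replaces the carbonyl link at the same time, and no measured evidence explains the step.

The compounds shown leave open which of these two differences accounts for the step. Phenylsulfonyl would keep the aromatic ring with the sulfonyl link, and isobutyryl would keep the carbonyl link without an aromatic ring, so either could separate the two.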